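The source may hold more compounds than are shown below. What is called first, only, known or untested is meant among the compounds shown, and "the series" means these compounds.

compound 1 `O=C(NCc1ccc(S(=O)(=O)c2cncc(C(F)(F)F)c2)cc1)N1Cc2ccncc2C1`: 83000 nM
compound 2 `O=C(NCc1ccc(S(=O)(=O)C2CCN(C3COC3)CC2)cc1)N1Cc2ccncc2C1`: 121000 nM

For the measured compounds named here, in a physicochemical assay for solubility, in phosphate buffer, with a stated time of 24 h, at pH 7.4, tested at 100 uM (a lower number here means a less soluble compound, a higher number a more soluble compound), compound 2, at 121000 nM on the numbers so far, lies within the scatter of compound 1, so the two cannot be put in order. Compound 3 `CN1CCN(S(=O)(=O)c2ccc(CNC(=O)N3Cc4ccncc4C3)cc2)CC1` has not yet been measured. It differs from compound 2 in one place, with 4-methylpiperazin-1-yl in place of 1-(oxetan-3-yl)piperidin-4-yl on a sulfonyl sulfur. Going by the values given here, one measured step bears on this, at the same kind of sulfonyl sulfur (a 1.5-fold higher number from compound 1 to compound 2 (0.16 log units; within the scatter)), and it stayed within the scatter although 1-(oxetan-3-yl)piperidin-4-yl replaced 5-(trifluoromethyl)pyridin-3-yl there. Among the compounds with values here, no measured compound carries 4-methylpiperazin-1-yl, so this single step is thin support. Even so, no step beyond the scatter is expected in this assay for this change, and no direction is favoured with any confidence. The expected step is small (a 1.1-fold lower number from compound 2 to compound 3 (0.04 log units; within the scatter)). Compound 3 is estimated at 110000 nM (expected range 60000 nM to 170000 nM).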

Compound 3, solubility: 160000 nM
Compound 3: the middle estimate sits 1.5-fold (0.16 log units) below what was measured; the measured number falls inside the stated range.
By their numbers in this assay, from the lowest: compounds 1, 2 and 3 (each within the scatter of the next).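

In this assay, a third group on the sulfonyl sulfur leaves the picture as it was, with 4-methylpiperazin-1-yl in place of 1-(oxetan-3-yl)piperidin-4-yl (a 1.3-fold higher number from compound 2 to compound 3 (0.12 log units; within the scatter)) and in place of 5-(trifluoromethyl)pyridin-3-yl (a 1.9-fold higher number from compound 1 to compound 3 (0.29 log units; within the scatter)), and both steps lie within the scatter. For the compounds shown here, the earlier pair offered only one such comparison, whereas three groups now stand at this position, and they differ in their rings and hetero atoms: 4-methylpiperazin-1-yl has one six-membered non-aromatic ring with 2 hetero atoms, while 1-(oxetan-3-yl)piperidin-4-yl also carries a four-membered ring. Among compounds 1, 2 and 3, no exchange at this position gives a step beyond the scatter, no compound goes against this, and the three cannot be put in order.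

Nothing shown accounts for why these numbers stay within the scatter of one another. As far as these compounds go, whether a carboxylic acid, a primary amine or a longer alkyl chain on the same sulfonyl sulfur would give a step beyond the scatter remains open, as does whether a change elsewhere in the shared core would do so.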